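Replacing chloro with trifluoromethyl on compound 1

This account rests on a few compounds, and the source may have more. Where it says the series, first, only, none or still open, it means among the compounds named here.

In a functional assay on LOX IMVI cells (Homo sapiens) for inhibition, read by sulforhodamine B assay, with a stated time of 48 h (a lower number here means a stronger inhibitor of growth, a higher number a weaker inhibitor of growth), compound 1 `COc1cc2nc(-c3ccc(Cl)cc3)cc(OCCCN3CCC(O)CC3)c2cc1OC` gives 227 nM and compound 2 `COc1cc2nc(-c3ccc(Cl)cc3)cc(OCCCN3CCCC3)c2cc1OC` gives 191 nM. These two values lie within the scatter of each other, so the measurements so far show no order of potency. Compound 3 `COc1cc2nc(-c3ccc(C(F)(F)F)cc3)cc(OCCCN3CCC(O)CC3)c2cc1OC` keeps the shared core and the side chain of compound 1 and changes one group: trifluoromethyl in place of chloro on an aromatic carbon. Trifluoromethyl stands in place of chloro on an aromatic carbon, so 4-chlorophenyl becomes 4-(trifluoromethyl)phenyl. Among the compounds with values here, the only measured step, a 1.2-fold lower number from compound 1 to compound 2 (0.07 log units; within the scatter), puts pyrrolidin-1-yl in place of 4-hydroxypiperidin-1-yl on the saturated chain. Within the data shown here, that step lies elsewhere in the molecule, and no measured compound varies the chloro group, so the data give neither a direction nor a size for this change. No step beyond the scatter is therefore expected in this assay, although the range has to stay wide. The estimated step is a 1.1-fold higher number from compound 1 to compound 3 (0.02 log units; within the scatter). Compound 3 is expected at 240 nM, with an estimated range from 100 nM to 600 nM.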

Compound 3, concentration for 50% growth inhibition: 190 nM
Compound 3: middle estimate off by 1.3-fold (0.10 log units), on the high side; the measured number falls inside the stated range.
By their numbers in this assay, from the lowest: compounds 3, 2 and 1 (each within the scatter of the next).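

In this assay, the first variation at this aromatic carbon gives a 1.2-fold lower number from compound 1 to compound 3 (0.08 log units; within the scatter), so this single pair shows no separation between chloro and trifluoromethyl. The exchange puts 4 heavy atoms where 1 heavy atom stood, para to a large group, and the number stays within the scatter; with the 4-hydroxypiperidin-1-yl side chain held fixed, this position therefore accepts the change from 4-chlorophenyl to 4-(trifluoromethyl)phenyl without a readable shift in growth inhibition. No measurement bears on why the two groups read alike, and the result carries no explanation.

The compounds shown leave open whether the same holds for other groups on this carbon, such as a methoxy group, a nitrile, a primary amine or a carboxylic acid, any of which could mark out how far this position stays insensitive to substitution. They also leave open whether trifluoromethyl reads the same when paired with the pyrrolidin-1-yl side chain, since the chloro to trifluoromethyl step is available here only with 4-hydroxypiperidin-1-yl.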